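Replacing 3,4-dichlorophenyl with thiophen-3-yl

This account rests on a few compounds, and the source may have more. Where it says the series, first, only, none or still open, it means among the compounds named here.

Within the data shown here, in a functional assay on MOLT-4 cells (Homo sapiens) for antiproliferative activity (a lower number here means a stronger inhibitor, a higher number a weaker inhibitor), compound 2 (`COc1cc(C(=O)c2sc(-c3ccc(Cl)c(Cl)c3)cc2N)cc(OC)c1OC`) gives 270 nM, the higher of the two numbers so far, while compound 1 (`COc1cc(C(=O)c2sc(-c3ccc(Cl)cc3)cc2N)cc(OC)c1OC`) gives 77 nM. Compound 3 (`COc1cc(C(=O)c2sc(-c3ccsc3)cc2N)cc(OC)c1OC`) keeps the shared core and carries thiophen-3-yl in place of 3,4-dichlorophenyl on an aromatic carbon. Among the measured compounds shown here, the only measured step is a 3.5-fold higher number from compound 1 to compound 2 (0.54 log units; beyond the scatter), a modest change with chloro in place of hydrogen on an aromatic carbon. For the measured compounds named here, no measured step covers thiophen-3-yl, so this is a loose guide. Compound 3 has no chloro group, and on the strength of that one step it is expected to sit nearer compound 1 than compound 2. The expected change is a 2.7-fold lower number from compound 2 to compound 3 (0.43 log units; beyond the scatter), a modest move toward a lower number in this assay. For compound 3 the estimated value is 100 nM, with an expected range of 25 nM to 400 nM.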

Compound 3, half-maximal inhibitory concentration: 8.8 nM
Compound 3: the middle estimate sits 11-fold (1.06 log units) above what was measured; the whole stated range lies above it.
By their numbers in this assay, from the lowest: compound 3; then compound 1; then compound 2.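

In this assay, thiophen-3-yl in place of 3,4-dichlorophenyl gives a 31-fold lower number from compound 2 to compound 3 (1.49 log units; beyond the scatter), and thiophen-3-yl in place of 4-chlorophenyl gives an 8.8-fold lower number from compound 1 to compound 3 (0.94 log units; beyond the scatter). The position on the aromatic carbon next to the ring sulfur therefore does not depend on a six-membered aromatic ring of carbon only, and the five-membered aromatic ring with 1 sulfur gives the lowest of the three numbers, whereas the earlier pair showed only the effect of adding a chloro group. Nothing measured here accounts for the size of these steps.

The compounds shown do not separate the loss of chloro from the change of ring, a separation that plain phenyl at this position would provide. Also open, on these data alone, is how pyridin-3-yl, or a thiophen-3-yl carrying a methyl group, would read here.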